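The source may report more compounds than this note shows. Statements on the series, on what has been measured and on what is new or still open speak of the compounds shown alone.

Working notes on the series. In a functional assay on PC-3 cells (Homo sapiens) for antiproliferative activity, read by WST assay, with a stated time of 3 days (on this read-out higher numbers stand for weaker inhibition and lower numbers for stronger inhibition), compound 1 `CCCCCCCOc1c(-c2cc(OC)c(OC)c(OC)c2)oc2ccccc2c1=O` gives only a limit, > 50000 nM, and no number. Compound 2 `CCN(CC)CCCCOc1c(-c2cc(OC)c(OC)c(OC)c2)oc2ccccc2c1=O` reads 13700 nM, and compound 3 `CCCN(CCC)CCCCCOc1c(-c2cc(OC)c(OC)c(OC)c2)oc2ccccc2c1=O` reads 2600 nM, the lower of the two actual numbers.

Compound 4 `CCCCCN(CCCCC)CCCCOc1c(-c2cc(OC)c(OC)c(OC)c2)oc2ccccc2c1=O` differs from compound 3 by dipentylamino in place of (dipropylamino)methyl on a saturated chain carbon, four bonds along the chain from an oxygen on an aromatic ring.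

Within the data shown here, the closest precedent is a 5.3-fold lower number from compound 2 to compound 3 (0.72 log units; beyond the scatter), a modest step beyond the scatter, though it rests on a single pair. The steps of an at least 3.6-fold lower number from compound 1 to compound 2 (0.56 log units; beyond the scatter) and an at least 19-fold lower number from compound 1 to compound 3 (1.28 log units; beyond the scatter) both start from a limit, so they set no size for this change. Going by a 5.3-fold lower number from compound 2 to compound 3 (0.72 log units; beyond the scatter), a further fall in this assay is expected, but a smaller one, possibly not beyond the scatter. The expected move is a 1.7-fold lower number from compound 3 to compound 4 (0.24 log units; within the scatter). For compound 4 the estimated value is 1500 nM, with an expected range of 500 nM to 6000 nM.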

Compound 4, half-maximal inhibitory concentration: 7900 nM
For compound 4 the middle estimate is 5.3-fold (0.72 log units) below the measured one, outside the stated range (above it).
By their numbers in this assay, from the lowest: compound 3; then compounds 4 and 2 (each within the scatter of the next). At a limit, above all of these: compound 1.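

In this assay, the larger dipentylamino group does not continue the fall seen with (dipropylamino)methyl (a 3.0-fold higher number from compound 3 to compound 4 (0.48 log units; beyond the scatter)). At this place, on a saturated chain carbon, four bonds along the chain from an oxygen on an aromatic ring, dipentylamino and diethylamino cannot be told apart (a 1.7-fold lower number from compound 2 to compound 4 (0.24 log units; within the scatter)), so the number does not fall steadily as the group grows, and compound 4 goes against any such trend. The remaining step (an at least 6.3-fold lower number from compound 1 to compound 4 (0.80 log units; beyond the scatter)) starts from a limit and cannot be read for size: the limit of > 50000 nM in this assay, at which 1 of the 4 values shown sits.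

Going by these compounds, how dipropylamino would read on the shorter chain of compound 2 and compound 4 remains open, so the shares of chain length and amine substituents in the lower number of compound 3 stay unsettled. On these data alone, how a ring amine such as piperidine would read at this place also remains open.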